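Aryl replacement at the carbon double-bonded to nitrogen

The source may report more compounds than this note shows. Statements on the series, on what has been measured and on what is new or still open speak of the compounds shown alone.

Compound 1 `CCCSc1nc(N/N=C/c2ccc(C)cc2)c2nnn(Cc3ccccc3)c2n1` gives > 64000 nM, a limit.
Compound 2 `CCCSc1nc(N/N=C/c2ccc([N+](=O)[O-])cc2)c2nnn(Cc3ccccc3)c2n1` gives 6640 nM.

Compound 1 sits at the limit of > 64000 nM in this assay, at which 1 of the 2 values shown sits, in a functional assay on ECa-109 cells (Homo sapiens) for antiproliferative activity, read by MTT assay, with a stated time of 72 h; a lower number here means a stronger inhibitor, a higher number a weaker inhibitor. Going by the values given here, compound 2 is the only compound with a number in this assay, at 6640 nM, and the single measured step is an at least 9.6-fold lower number from compound 1 to compound 2 (0.98 log units; beyond the scatter). Compound 3 `CCCSc1nc(N/N=C/c2c[nH]c3ccccc23)c2nnn(Cc3ccccc3)c2n1` carries the change (1H-indol-3-yl in place of 4-nitrophenyl on a carbon with a double bond to nitrogen). Among the compounds with values here, no measured step covers an indol-3-yl group; the only step known gained at least modestly when nitro replaced methyl, and compound 3 gives up the nitro group while bringing in a hydrogen-bond donor in place of two acceptors. The expected step is therefore a 3.0-fold higher number from compound 2 to compound 3 (0.48 log units; beyond the scatter), a move toward weaker inhibition with wide uncertainty. Compound 3 is estimated at 20000 nM, with a range from 5000 nM to 64000 nM.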

Compound 3, half-maximal inhibitory concentration: 8690 nM
Compound 3: middle estimate off by 2.3-fold (0.36 log units), on the high side; the range from low to high includes it.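

In this assay, the nitro group is not needed for measurable activity at this position: a 1.3-fold higher number from compound 2 to compound 3 (0.12 log units; within the scatter), so 4-nitrophenyl and 1H-indol-3-yl, which differ in ring make-up and in hydrogen-bond donors and acceptors, cannot be told apart here. The 4-methylphenyl group is thus the outlier of the three, with an at least 7.3-fold lower number from compound 1 to compound 3 (0.86 log units; beyond the scatter), a second step beyond the scatter that does not depend on the nitro group. That step is only a bound, as compound 1 is held as a limit: the limit of > 64000 nM in this assay, at which 1 of the 3 values shown sits.

From the compounds shown here alone, whether an amine, a methoxy group or a plain hydrogen in place of the nitro group would side with compound 1 or with compound 2 and compound 3 stays open. Also open, going by these compounds, is whether this pattern holds with a different chain on the sulfur of the shared core.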